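A few compounds are considered here, and "the series" means these few. Any claim that something is new, unique, unknown or untested is made for them only; others in the source may bear on it.

Measured so far:
- compound 1, `Nc1n[nH]c2cc(-c3ccccn3)[nH]c(=O)c12`: in an assay on isolated protein for inhibition of MAP kinase-activated protein kinase 2 (Homo sapiens), read by mobility shift assay, tested at 30 uM (a higher number here means more inhibition at the concentration tested (going by the name of the read-out), a lower number less inhibition), compound 1 gives 41%
- compound 2, `Cn1nc(N)c2c(=O)[nH]c(-c3ccccc3)cc21`: in this assay compound 2 gives 37%

Compound 2 stands next to compound 1 on these numbers; the gap between the two lies within the usual scatter of repeated measurements, so the two readings cannot be told apart and neither number can be called the higher one.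

Compound 3, `Cn1nc(N)c2c(=O)[nH]c(-c3ccccn3)cc21`, differs from compound 2 in one place: pyridin-2-yl in place of phenyl on an aromatic carbon. Within the data shown here, no measured pair shows this exact change on a shared core, so no step size can be read off. Compound 1, which carries pyridin-2-yl on a different core, and compound 2, which carries phenyl, give readings that do not separate beyond the scatter. The step is therefore expected to be small, in no clear direction, and not beyond the scatter.

For compound 3 in this assay an inhibition of 40% is estimated, with a range from 25% to 55%. The expected step of a number 3 percentage points higher from compound 2 to compound 3 (within the scatter) is within the scatter.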

Compound 3, a percentage reported as inhibition, at one concentration (the size of the read-out at that concentration, not a potency): 36%
Estimate against measurement, compound 3: 4 percentage points above, within the range that was stated.
By their numbers in this assay, from the lowest: compounds 3, 2 and 1 (each within the scatter of the next).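

On the shared core, pyridin-2-yl in place of phenyl on this aromatic carbon next to the ring nitrogen gives in this assay a number 1 percentage points lower from compound 2 to compound 3 (within the scatter) and so adds a hydrogen-bond acceptor without a reading that can be separated from that of compound 2. Methyl in place of hydrogen on an aromatic nitrogen can now be read on its own, with pyridin-2-yl held constant, and gives a number 5 percentage points lower from compound 1 to compound 3 (within the scatter) for this change. No independent data bear on either step.

From the compounds shown here alone, whether an amine or a carboxylic acid in place of the six-membered aromatic ring on this carbon would give a reading beyond the scatter stays open. The same holds for a longer chain than methyl on the aromatic nitrogen.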